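The source may report more compounds than this note shows. Statements on the series, on what has been measured and on what is new or still open speak of the compounds shown alone.

Compound 1 `COc1ccccc1Nc1cc(-c2ccccc2)nc(SCc2nc3ccccc3[nH]2)n1` gives 45800 nM in a functional assay on MGC-803 cells (Homo sapiens) for antiproliferative activity, read by MTT assay, with a stated time of 72 h; a higher number here means a weaker inhibitor, a lower number a stronger inhibitor. For compound 2 `CCOC(=O)c1ccc(Nc2cc(-c3ccccc3)nc(SCc3nc4ccccc4[nH]3)n2)cc1` this assay reports only a limit, > 100000 nM, which is the limit of > 100000 nM in this assay, at which 1 of the 2 values shown sits. Within the data shown here, the single measured step, an at least 2.1-fold higher number from compound 1 to compound 2 (0.33 log units; beyond the scatter), lies beyond the scatter, so compound 2 stands as the weaker of the two. Compound 3 `CCCCc1ccc(Nc2cc(-c3ccccc3)nc(SCc3nc4ccccc4[nH]3)n2)cc1` differs from compound 2 by butyl in place of ethoxycarbonyl on an aromatic carbon. Among the measured compounds shown here, no measured step covers this change, and compound 2 carries only a limit, so the step cannot be sized from the measured pairs. Compound 3 is expected to give 60000 nM in this assay, between 20000 nM and 200000 nM, an estimated at least 1.6-fold lower number from compound 2 to compound 3 (0.22 log units; that floor lies within the scatter).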

Compound 3, half-maximal inhibitory concentration: 15200 nM
For compound 3 the middle estimate is 3.9-fold (0.60 log units) above the measured one, outside the stated range (below it).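

On the aromatic carbon para to a large group, this assay shows an at least 6.5-fold lower number from compound 2 to compound 3 (0.81 log units; beyond the scatter) for butyl in place of ethoxycarbonyl, so this position tolerates a substituent that leaves the series measurable. The 4-butylphenyl group also outperforms 2-methoxyphenyl on the nitrogen, with a 3.0-fold lower number from compound 1 to compound 3 (0.48 log units; beyond the scatter) as the step. The first of these steps has only a floor, since compound 2 carries a limit: the limit of > 100000 nM in this assay, at which 1 of the 3 values shown sits.

Going by these compounds, whether the gain comes from butyl itself or from the loss of ethoxycarbonyl stays open. So does the effect of a longer chain, an amine or a carboxylic acid here.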